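The compounds below may be only part of what the source reports. "The series", "measured", "known", "first", "only" and "open" are said of these compounds alone.

Measured in a functional assay on PC-3 cells (Homo sapiens) for antiproliferative activity, read by MTT assay, with a stated time of 24 h; on this read-out higher numbers stand for weaker inhibition and lower numbers for stronger inhibition:
Compound 1 `CCn1c(C(=O)N[C@@H](C)C(=O)OC)ccc1C(CC)(CC)c1ccc(OCS(=O)(=O)c2ccccc2)c(C)c1`: > 50000 nM (a limit)
Compound 2 `CCn1c(C(=O)N[C@@H](CO)CCCO)ccc1C(CC)(CC)c1ccc(OCS(=O)(=O)c2ccccc2)c(C)c1`: 13400 nM
Compound 3 `CCn1c(C(=O)NC2(C(=O)O)CC2)ccc1C(CC)(CC)c1ccc(OCS(=O)(=O)c2ccccc2)c(C)c1`: 26300 nM

Compound 1 stands at a limit of this assay, > 50000 nM, and not at a number. Going by the values given here, compound 3 gives 26300 nM and sits level with compound 2, the only other compound with a true number: a 2.0-fold higher number from compound 2 to compound 3 (0.29 log units; within the scatter). Measured against the limit of compound 1, the two steps are an at least 3.7-fold lower number from compound 1 to compound 2 (0.57 log units; beyond the scatter) and an at least 1.9-fold lower number from compound 1 to compound 3 (0.27 log units; that floor lies within the scatter).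

Compound 4 `CCn1c(C(=O)N[C@H](C(=O)O)C(C)C)ccc1C(CC)(CC)c1ccc(OCS(=O)(=O)c2ccccc2)c(C)c1` keeps the shared core and changes only the group on the amide-type nitrogen: 1-carboxy-2-methylpropyl in place of 1-carboxycyclopropyl on an amide-type nitrogen. In words, 1-carboxy-2-methylpropyl replaces 1-carboxycyclopropyl. The closest measured change between an open group and the three-membered ring is a 2.0-fold higher number from compound 2 to compound 3 (0.29 log units; within the scatter), so no step beyond the scatter is expected in this assay for this reverse change. The estimate amounts to a 1.1-fold lower number from compound 3 to compound 4 (0.02 log units; within the scatter), an expected step that stays within the scatter. Compound 4 is estimated at 25000 nM, with an expected range of 10000 nM to 50000 nM.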

Compound 4, half-maximal inhibitory concentration: 3650 nM
Compound 4: middle estimate off by 6.8-fold (0.84 log units), on the high side, outside the stated range (below it).
By their numbers in this assay, from the lowest: compound 4; then compounds 2 and 3 (each within the scatter of the next). At a limit, above all of these: compound 1.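

On the amide-type nitrogen, the open 1-carboxy-2-methylpropyl group and the ring-bearing 1-carboxycyclopropyl group are not interchangeable in this assay: there is a 7.2-fold lower number from compound 3 to compound 4 (0.86 log units; beyond the scatter). The two earlier compounds with true numbers lay within the scatter of each other, whereas this series now shows a clear separation at this position, with a 3.7-fold lower number from compound 2 to compound 4 (0.56 log units; beyond the scatter). Compound 1 stands at a limit and not at a number, so an at least 13-fold lower number from compound 1 to compound 4 (1.13 log units; beyond the scatter) gives only a floor for that step: the limit of > 50000 nM in this assay, at which 1 of the 4 values shown sits.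

The compounds shown do not tell whether the branched chain, the defined stereocentre or the loss of the three-membered ring carries the step. From the compounds shown here alone, it also remains open how an unbranched chain, a methyl ester or an amine in place of the carboxylic acid would read out on this group.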